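This account rests on a few compounds, and the source may have more. Where it says the series, first, only, none or still open, it means among the compounds named here.

The study concerns an assay on isolated protein for inhibition of thiosulfate sulfurtransferase (Homo sapiens); on this read-out higher numbers stand for weaker inhibition and lower numbers for stronger inhibition. Of the compounds shown here, three have been measured so far. Compound 1 `O=S(=O)(Nc1ccc(-c2nc3cc(NS(=O)(=O)c4ccc(C(F)(F)F)cc4)ccc3o2)cc1)c1ccc(C(F)(F)F)cc1` reaches only the limit of this assay, giving > 100000 nM. Compound 2 `O=S(=O)(Nc1ccc(-c2nc3cc(NS(=O)(=O)c4cccc5ccccc45)ccc3o2)cc1)c1cccc2ccccc12` likewise reaches only the limit, giving > 100000 nM. Compound 3 `COc1ccc(S(=O)(=O)Nc2ccc3oc(-c4ccc(NC(=O)c5ccc(Cl)s5)cc4)nc3c2)cc1` also stops at the limit, giving > 100000 nM. Where compound 3 stands among the numbers shown is therefore plain: it sits at the limit of > 100000 nM in this assay, at which 3 of the 3 values shown sit, and none of the three compounds has a measured value to set it apart from the others.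

Compound 4 `COc1ccc(S(=O)(=O)Nc2ccc(-c3nc4cc(NS(=O)(=O)c5ccc(OC)cc5)ccc4o3)cc2)cc1` has not yet been measured in this assay. It differs from compound 3 by (4-methoxyphenyl)sulfonyl in place of (5-chlorothiophen-2-yl)carbonyl on a nitrogen on an aromatic ring. Among the measured compounds shown here, no step between measured compounds is available to set the size of this change. What is available is that compound 1 and compound 2, which like compound 4 carry sulfonyl groups in place of a carbonyl, stopped at the limit, as did compound 3. The step is therefore expected to be a step that the limit leaves unreadable from compound 3 to compound 4, that is, no movement beyond the scatter that these numbers can reveal. Compound 4 is estimated at 150000 nM, within the range 30000 nM to 1000000 nM, with a strong chance that this assay once more reports only a limit.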

Compound 4, half-maximal inhibitory concentration: > 100000 nM
Compound 4: only a limit was reported; the forecaster's own chance of this, stated with the estimate: 80%; the middle value lies beyond the limit too.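

No step can be read from compound 3 to compound 4, because both compounds stop at the same limit, as do compound 1 and compound 2: the limit of > 100000 nM in this assay, at which 4 of the 4 values shown sit. The compounds shown leave open whether they differ at all in inhibition, and which change to the shared core, if any, would yield a measured number.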